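From 4-methylpiperazin-1-yl to 3-(dimethylamino)pyrrolidin-1-yl on a carbonyl

The compounds below may be only part of what the source reports. "The series", "measured", "known", "first", "only" and "open" are said of these compounds alone.

Of the compounds shown here, two with the same core have been measured so far. In a functional assay on HCT-116 cells (Homo sapiens) for inhibition (a lower number here means that less compound is needed, a higher number that more compound is needed for the effect), compound 1 (`COc1cc(N2CCC(C(=O)N3CCC(N(C)C)C3)CC2)ccc1Nc1nc(NC2CCCCC2)c2nc[nH]c2n1`) gives 77 nM and compound 2 (`COc1cc(N2CCC(CC(=O)N3CCN(C)CC3)CC2)ccc1Nc1nc(NC2CCCCC2)c2nc[nH]c2n1`) gives 65 nM, two values that lie within the scatter of each other. Going by the values given here, compound 2 therefore stands level with the only other measured compound.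

Compound 3 (`COc1cc(N2CCC(CC(=O)N3CCC(N(C)C)C3)CC2)ccc1Nc1nc(NC2CCCCC2)c2nc[nH]c2n1`) differs from compound 2 in one group: 3-(dimethylamino)pyrrolidin-1-yl in place of 4-methylpiperazin-1-yl on a carbonyl carbon. Put simply, 3-(dimethylamino)pyrrolidin-1-yl comes in place of 4-methylpiperazin-1-yl on a carbonyl carbon.

Among the compounds with values here, only one measured step bears on this change, a 1.2-fold lower number from compound 1 to compound 2 (0.07 log units; within the scatter), and it stays within the scatter. In that step, ((4-methylpiperazin-1-yl)carbonyl)methyl replaced (3-(dimethylamino)pyrrolidin-1-yl)carbonyl, so the same two ring groups were exchanged, but the added methyl part changed at the same time. Within the data shown here, no measured pair shows the ring exchange alone, which makes this evidence thin.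

No change beyond the scatter is expected in this assay, and the estimated step is a 1.1-fold higher number from compound 2 to compound 3 (0.03 log units; within the scatter). Compound 3 is estimated at 70 nM, with an expected range from 30 nM to 160 nM.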

Compound 3, half-maximal effective concentration: 97 nM
The estimate for compound 3 lay 1.4-fold (0.14 log units) below the measured number; the measured number falls inside the stated range.
By their numbers in this assay, from the lowest: compounds 2, 1 and 3 (each within the scatter of the next).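

In this assay, the exchange of 4-methylpiperazin-1-yl for 3-(dimethylamino)pyrrolidin-1-yl on a carbonyl carbon can now be read on its own, with the rest of the molecule unchanged, and it gives a 1.5-fold higher number from compound 2 to compound 3 (0.17 log units; within the scatter). The other part of the earlier mixed step can also be read separately: with 3-(dimethylamino)pyrrolidin-1-yl kept, ((3-(dimethylamino)pyrrolidin-1-yl)carbonyl)methyl in place of (3-(dimethylamino)pyrrolidin-1-yl)carbonyl on a saturated ring carbon gives a 1.3-fold higher number from compound 1 to compound 3 (0.10 log units; within the scatter). Across these three compounds, neither change takes the number beyond the usual scatter of the assay, and no measurement shown speaks to the reason for these numbers.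

Going by these compounds, whether a longer chain in place of the methyl part, or a morpholine ring or an open-chain amine in place of either ring group on the carbonyl carbon, would give a step beyond the scatter remains open. All three numbers also come from this assay alone, so these compounds do not show whether the same small steps would appear in any other kind of test.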